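Swapping a Methoxyphenyl for Phenethyl: an Expected Outcome

The compounds below may be only part of what the source reports. "The series", "measured", "known", "first", "only" and "open" are said of these compounds alone.

Of the compounds shown here, two have so far been measured in an assay for inhibition of 3-hydroxy-3-methylglutaryl-coenzyme A reductase (Rattus norvegicus); on this read-out higher numbers stand for weaker inhibition and lower numbers for stronger inhibition. Compound 1 `COc1ccc(-c2cc(Cl)cc(Cl)c2/C=C/[C@@H]2C[C@@H](O)CC(=O)O2)cc1` gives 470 nM, the higher of the two numbers. Compound 2 `Cc1ccc(C)c(-c2ccc(Cl)c(Cl)c2)c1/C=C/[C@@H]1C[C@@H](O)CC(=O)O1` gives 13 nM, and the gap between the two lies well beyond the scatter of repeated measurements. Compound 3 `O=C1C[C@H](O)C[C@@H](/C=C/c2c(Cl)cc(Cl)cc2CCc2ccccc2)O1` has not yet been measured; it differs from compound 1 in a single place: phenethyl in place of 4-methoxyphenyl on an aromatic carbon. Among the measured compounds shown here, no step between measured compounds shows how such a change plays out, since compound 2 differs from compound 1 in several places at once. With nothing to anchor the step, the expected shift is modest, a 1.3-fold higher number from compound 1 to compound 3 (0.11 log units; within the scatter), and may well fall within the scatter. Compound 3 is therefore expected to give about 600 nM in this assay, with a plausible range from 150 nM to 2500 nM.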

Compound 3, half-maximal inhibitory concentration: 430 nM
Beside the measured number, compound 3's estimate is 1.4-fold (0.14 log units) above it; measured number inside the range.
By their numbers in this assay, from the lowest: compound 2; then compounds 3 and 1 (each within the scatter of the next).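

At this aromatic carbon on the core of compound 1, phenethyl in place of 4-methoxyphenyl gives, in this assay, a 1.1-fold lower number from compound 1 to compound 3 (0.04 log units; within the scatter). The two groups have the same heavy-atom count and each carries one six-membered aromatic ring, but the oxygen and the single hydrogen-bond acceptor of 4-methoxyphenyl are absent from phenethyl, and this exchange leaves no difference beyond the scatter. No measurement is available that explains this result.

The compounds shown leave open whether an amine, a carboxylic acid or a longer chain ending in phenyl at this same carbon would also stay within the scatter of compound 1. They also leave open which of the several differences between compound 1 and compound 2 accounts for the lower number of compound 2.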